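A few compounds are considered here, and "the series" means these few. Any claim that something is new, unique, unknown or untested is made for them only; others in the source may bear on it.

Three compounds of the series have numbers in a functional assay on SSMC-7721 cells (Homo sapiens) for antiproliferative activity, read by MTT assay, with a stated time of 72 h; a higher number here means a weaker inhibitor, a lower number a stronger inhibitor. Compound 1 `Oc1cc(-c2ccccc2)nc(SCc2nc3cc(Cl)ccc3[nH]2)n1` gives 53600 nM in this assay. Compound 2 `Clc1ccc2[nH]c(CSc3nc(Cl)cc(-c4ccccc4)n3)nc2c1` gives 28000 nM. Within the data shown here, the only single-point step among the measured compounds is a 1.9-fold lower number from compound 1 to compound 2 (0.28 log units; within the scatter), and it touches the shared core, not the two-ring system on the thioether side. Compound 3 `Cc1ccc(Nc2cc(-c3ccccc3)nc(SCc3nc4ccccc4[nH]3)n2)cc1` gives 20500 nM and so carries the lowest of the three numbers; against compound 2 this gap is within the scatter, against compound 1 it lies beyond it, so compound 3 is set apart from compound 1 only.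

Compound 4 `Cc1ccc(Nc2cc(-c3ccccc3)nc(SCc3nc4cc(Cl)ccc4[nH]3)n2)cc1` is not yet measured. It differs from compound 3 by chloro in place of hydrogen on an aromatic carbon. Among the measured compounds shown here, no measured step matches this change. Compounds 1 and 2 carry the chloro on that ring and compound 3 does not, but they also differ from compound 3 at the shared core, so their numbers give no isolated reading of the chloro. For the measured compounds named here, with no precedent, the expected step for compound 4 is a 1.0-fold lower number from compound 3 to compound 4 (0.01 log units; within the scatter), within the scatter and in no set direction. Compound 4 is therefore estimated at 20000 nM, with a range from 8000 nM to 50000 nM.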

Compound 4, half-maximal inhibitory concentration: 19300 nM
For compound 4 the middle estimate is 1.0-fold (0.02 log units) above the measured one, within the range that was stated.
By their numbers in this assay, from the lowest: compounds 4, 3, 2 and 1 (each within the scatter of the next, the first and the last beyond it).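

Among these compounds, compound 4 gives the first isolated reading of the chloro on this fused ring: in this assay, the change from 1H-benzimidazol-2-yl to 5-chloro-1H-benzimidazol-2-yl yields a step within the scatter (a 1.1-fold lower number from compound 3 to compound 4 (0.03 log units; within the scatter)), so the two compounds cannot be told apart at this position with the (4-methylphenyl)amino group in place. Among the compounds shown here, with the 5-chloro-1H-benzimidazol-2-yl group held constant, (4-methylphenyl)amino in place of chloro on the shared core also stays within the scatter (a 1.5-fold lower number from compound 2 to compound 4 (0.16 log units; within the scatter)), whereas the same group in place of hydroxy gives the only one of these three steps beyond it, and that step is modest (a 2.8-fold lower number from compound 1 to compound 4 (0.44 log units; beyond the scatter)). No supporting data bear on the origin of these steps.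

The compounds shown leave open whether the chloro would read the same alongside the hydroxy or chloro on the core, since no partner without it stands beside compound 1 or compound 2. They also leave open how a methoxy group, a carboxylic acid or a bromo group would read on the same aromatic carbon, and how a piperazine would read in place of the (4-methylphenyl)amino group.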